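Hydroxy in Place of Chloro: From Compound 1 to Compound 4

A few compounds are considered here, and "the series" means these few. Any claim that something is new, unique, unknown or untested is made for them only; others in the source may bear on it.

Compound 1 `CS(=O)(=O)Nc1ccc(Cl)c2c1CCCC2c1c[nH]cn1` gives 4.35 in a functional assay on Urethra for agonist activity at Alpha-1A adrenergic receptor (Oryctolagus cuniculus); a higher number here means a more potent compound, by a factor of ten per unit of this negative logarithm, a lower number a less potent compound.
Compound 2 `CS(=O)(=O)Nc1cccc2c1CCCCC2c1c[nH]cn1` gives 4.72 in this assay.
Compound 3 `CC(c1cccc(NS(C)(=O)=O)c1)c1c[nH]cn1` gives 5.38 in this assay.

Among the three measured compounds, compound 1 has the lowest number. Its nearest neighbour is compound 2, whose value is higher by a margin beyond the usual scatter; compound 3 stands furthest away, higher still and likewise beyond the scatter. Within the data shown here, none of the three measured compounds differs from another in a single place, so no measured step is available to lean on.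

Compound 4 `CS(=O)(=O)Nc1ccc(O)c2c1CCCC2c1c[nH]cn1` has not yet been measured in this assay. It differs from compound 1 in one place: hydroxy in place of chloro on an aromatic carbon. With nothing measured for this exchange, the expectation rests only on compound 1 holding the lowest of the three numbers and on the change being small. The step of a number 0.35 log units higher from compound 1 to compound 4 (beyond the scatter) is expected to be a modest one upward, not clearly beyond the scatter. Compound 4 is expected to give about 4.7 in this assay, within a range from 4 to 5.4.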

Compound 4, negative logarithm of the half-maximal effective concentration: 4.61
For compound 4 the middle estimate is 0.09 log units above the measured one, and the stated range covers the measured number.
By their numbers in this assay, from the lowest: compounds 1, 4 and 2 (each within the scatter of the next, the first and the last beyond it); then compound 3.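

In this assay, among these compounds, hydroxy in place of chloro on an aromatic carbon, para to a methanesulfonamido group, offers the single-place comparison that the earlier compounds lacked: a number 0.26 log units higher from compound 1 to compound 4 (within the scatter). On the core of compound 1, then, this position takes a hydroxy, with its hydrogen-bond donor and hydrogen-bond acceptor, in place of a chloro that has neither, with no difference that can be told from the scatter. The data shown offer no explanation for this outcome.

On these data alone, what a methoxy group, an amine or a carboxylic acid would give in the same place remains open. So does whether hydroxy in place of hydrogen at the matching position on the core of compound 2 would read the same way.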